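Acyl group change at the amide carbonyl: compound 3 to 4

A few compounds are considered here, and "the series" means these few. Any claim that something is new, unique, unknown or untested is made for them only; others in the source may bear on it.

Measured so far in a functional assay on HCT-116 cells (Homo sapiens) for inhibition, read by MTT assay, with a stated time of 48 h; on this read-out lower numbers stand for stronger inhibition and higher numbers for weaker inhibition:
compound 1 `COC(=O)c1cc(CNc2cc(OC)c(OC)c(OC)c2)ccc1OC` gives 38100 nM
compound 2 `C=C(C)C(=O)N(Cc1ccc(OC)c(O)c1)c1cc(OC)c(OC)c(OC)c1` gives 200 nM
compound 3 `COc1ccc(CN(C(=O)C[Se]C#N)c2cc(OC)c(OC)c(OC)c2)cc1O` gives 310 nM

Compound 3 stands second highest of the three numbers in this assay. Its nearest neighbour is compound 2, and the two values lie within the scatter of each other; its furthest is compound 1, whose value is well beyond the scatter from that of compound 3.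

Compound 4 `C/C=C/C(=O)N(Cc1ccc(OC)c(O)c1)c1cc(OC)c(OC)c(OC)c1` is not yet measured. It differs from compound 3 at the carbonyl carbon: a group of 3 heavy atoms (3 carbon; no ring) in place of a group of 4 heavy atoms (2 carbon, 1 nitrogen, 1 selenium; no ring), on a carbonyl carbon

For the measured compounds named here, one measured step bears on this change. The step of a 1.6-fold higher number from compound 2 to compound 3 (0.19 log units; within the scatter) exchanged a group of 3 heavy atoms, all carbon, for the selenium-containing group on the same carbonyl carbon, and it stayed within the scatter. Compound 4 reverses that kind of exchange, restoring a group of 3 carbon heavy atoms with one double bond outside aromatic rings, though not the same group as in compound 2. Going by the values given here, no other pair touches this position, and compound 1 lacks the acyl group altogether.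

Accordingly, for compound 4 the step of a 1.2-fold lower number from compound 3 to compound 4 (0.09 log units; within the scatter) is expected to be small and not beyond the scatter, with a slightly lower number more likely than a higher one. Compound 4 is estimated at 250 nM in this assay, with a range from 100 nM to 650 nM.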

Compound 4, half-maximal inhibitory concentration: 55 nM
The estimate for compound 4 lay 4.5-fold (0.66 log units) above the measured number; the whole stated range lies above it.
By their numbers in this assay, from the lowest: compound 4; then compounds 2 and 3 (each within the scatter of the next); then compound 1.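

In this assay the acyl position had shown no clear separation, with a 1.6-fold higher number from compound 2 to compound 3 (0.19 log units; within the scatter); prop-1-en-1-yl now gives the first step at this carbonyl carbon that lies beyond the scatter, with a 5.6-fold lower number from compound 3 to compound 4 (0.75 log units; beyond the scatter). The more informative comparison is a 3.6-fold lower number from compound 2 to compound 4 (0.56 log units; beyond the scatter): 1-methylethenyl and prop-1-en-1-yl have the same count of heavy atoms, all carbon, so in these two compounds the number depends on how those atoms are arranged and not on how many there are. Nothing measured here accounts for this difference.

Still open, as far as these compounds go, is whether the double bond of prop-1-en-1-yl matters at all, which a saturated propyl group on the same carbonyl carbon would test, and whether a longer chain or a phenyl group there would lower the number further. Also open, from the compounds shown here alone, is whether the order of compound 4 against compound 2 and compound 3 would hold on cell lines other than the one used in this assay.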